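Series notes: dimethylcarbamoyl to azetidinylmethyl carbamoyl

This account rests on a few compounds, and the source may have more. Where it says the series, first, only, none or still open, it means among the compounds named here.

Measured:
compound 1 `Cn1cc(CNS(=O)(=O)c2ccccc2Nc2cc(-c3ccc4ccn(C)c4c3)c3nccnc3c2)cn1` — 38 nM
compound 2 `CN(C)C(=O)c1ccncc1Nc1cc(-c2ccc3ccn(C)c3c2)c2nccnc2c1` — 499 nM

In an assay for inhibition of 6-phosphofructo-2-kinase/fructose-2,6-bisphosphatase 3 (Homo sapiens), read by ADP-Glo, with a stated time of 2 h (on this read-out lower numbers stand for stronger inhibition and higher numbers for weaker inhibition), compound 2 gives the higher of the two numbers, and compound 1 sits well below it, a gap beyond the usual scatter. Compound 3 `CC(=O)N1CC(CNC(=O)c2ccncc2Nc2cc(-c3ccc4ccn(C)c4c3)c3nccnc3c2)C1` carries ((1-acetylazetidin-3-yl)methyl)amino in place of dimethylamino on a carbonyl carbon. For the measured compounds named here, no measured pair shows this change, so the size of the move can only be guessed; a moderate shift toward a lower number is expected, though one within the scatter would not surprise. Compound 3 is estimated at 200 nM, between 50 nM and 800 nM. This corresponds to an expected step of a 2.5-fold lower number from compound 2 to compound 3 (0.40 log units; beyond the scatter).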

Compound 3, half-maximal inhibitory concentration: 137 nM
Compound 3: middle estimate off by 1.5-fold (0.16 log units), on the high side; the range from low to high includes it.
By their numbers in this assay, from the lowest: compound 1; then compound 3; then compound 2.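

On the carbonyl carbon, ((1-acetylazetidin-3-yl)methyl)amino in place of dimethylamino gives a 3.6-fold lower number from compound 2 to compound 3 (0.56 log units; beyond the scatter) in this assay. This position therefore tolerates the larger group, with its four-membered non-aromatic ring and added hydrogen-bond donor and acceptor, without loss of inhibition. No supporting data speak to the reason for this step.

Which part of the new group accounts for the step remains open: the amide hydrogen, the azetidine ring or the acetyl group. Methylamino or an azetidinylmethylamino group with a free ring amine on the same carbonyl carbon would help separate these parts.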